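This account rests on a few compounds, and the source may have more. Where it says the series, first, only, none or still open, it means among the compounds named here.

Measured so far in an ADME assay on BJ cells (Homo sapiens) for cytotoxicity, read by CellTiter-Glo and resazurin assay, with a stated time of 72 h; a higher number here means that more compound is needed for the effect, a lower number that less compound is needed:

Compound 1 `CCCNCc1ccccc1OCCCCCC(=O)OCC`, which gives > 26000 nM, a limit of the assay rather than a number.
Compound 2 `CCCNCc1cccc(OCCCCCC(=O)OCC)c1`, which gives > 26000 nM, also only a limit.
Compound 3 `CCOC(=O)CCCCCOc1ccccc1C=O`, which gives > 26000 nM, again a limit.

Compound 1 and compound 2 share the same atoms joined differently; the difference between the two cores is not broken down here. From compound 1 to compound 3 the change is formyl in place of (propylamino)methyl on an aromatic carbon, and the step that the two limits leave unreadable from compound 1 to compound 3 cannot be read, because the limit of > 26000 nM in this assay, at which 3 of the 3 values shown sit, holds for both.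

Compound 4 `CCOC(=O)CCCCCOc1cccc(C=O)c1` is not yet measured in this assay. It differs from compound 2 by formyl in place of (propylamino)methyl on an aromatic carbon, the same kind of change as that from compound 1 to compound 3, but here meta to a large group rather than ortho to a large group. Among the measured compounds shown here, since every value so far sits at the limit (the limit of > 26000 nM in this assay, at which 3 of the 3 values shown sit), the expected step that the limit leaves unreadable from compound 2 to compound 4 is small and compound 4 is estimated at 40000 nM, most likely reported again only as a limit.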

Compound 4, half-maximal effective concentration: > 26000 nM
Compound 4: no number, only a limit (the forecaster's own chance of this, stated with the estimate: 90%); the middle value lies beyond the limit too.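

The step from compound 2 to compound 4 cannot be read, because both values are limits: the limit of > 26000 nM in this assay, at which 4 of the 4 values shown sit.

In this assay, as far as these compounds go, the concentration at which any of the four compounds takes effect stays open, as does any effect of formyl replacing (propylamino)methyl.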